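The compounds below may be only part of what the source reports. "The series", "measured", "known", "first", "only" and "open" are said of these compounds alone.

Compound 1 `c1ccc(C2Cc3nccn3C2)cc1`: in a functional assay on CHO cells for agonist activity at Alpha-1B adrenergic receptor (Homo sapiens), read by FLIPR and calcium flux (a higher number here means that more compound is needed for the effect, a lower number that less compound is needed), compound 1 gives > 10000 nM; > 10000 nM; > 10000 nM; > 10000 nM (4 entries), which is a limit of the assay.
Compound 2 `FC(F)Oc1ccccc1C1Cc2nccn2C1`: in this assay compound 2 gives "not determined" (no result reported).

On the numbers, compound 2 stands nowhere: it has no single value, and one further entry also carries no number. Compound 3 `Clc1ccccc1C1Cc2nccn2C1` differs from compound 2 by chloro in place of difluoromethoxy on an aromatic carbon. Going by the values given here, no measured step covers this change, and compound 2 offers no baseline, so neither the size nor the direction of the step in this assay can be read from the data. Compound 1 shows only a limit in this assay. Compound 3 is expected to give about 3000 nM in this assay, within 300 nM to 10000 nM.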

Compound 3, half-maximal effective concentration: 1100 nM
Beside the measured number, compound 3's estimate is 2.7-fold (0.44 log units) above it; the measured number falls inside the stated range.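

No new step can be read for compound 3: compound 2 has no single number in this assay, and compound 1 has only a limit there. From the compounds shown here alone, what chloro does in place of difluoromethoxy stays open. No measured evidence bears on this result.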